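The source may hold more compounds than are shown below. What is called first, only, known or untested is meant among the compounds shown, and "the series" means these compounds.

Working notes on the series in an ADME assay on TZM-b1 cells (Homo sapiens) for cytotoxicity, read by XTT assay, with a stated time of 3 days; on this read-out higher numbers stand for lower toxicity in this test and lower numbers for higher toxicity in this test.

Compound 1 `Cc1nc(C(NC(=O)C(=O)Nc2ccc(Cl)cc2)C2CCCCN2)sc1CO` gives in this assay only a limit, > 22000 nM. Compound 2 `Cc1nc(C(NC(=O)C(=O)Nc2ccc(Cl)c(F)c2)C2CCCCN2)sc1CO` gives 58400 nM in this assay. Compound 3 `Cc1nc(C(NC(=O)C(=O)Nc2ccc(F)cc2)C2CCCCN2)sc1CCO` gives in this assay only a limit, > 88000 nM. Compound 4 `Cc1nc(C(NC(=O)C(=O)Nc2ccc(F)cc2F)C2CCCCN2)sc1CCO` has not yet been run in this assay.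

From compound 1 to compound 2 the change is fluoro in place of hydrogen on an aromatic carbon. The step it made is a step that the limit leaves unreadable from compound 1 to compound 2; its size is not readable because the limit of > 22000 nM in this assay, at which 1 of the 3 values shown sits, holds the value of compound 1.

Compound 3 and compound 1 differ in their cores; that difference is not broken down here. From compound 3 to compound 4 the change is fluoro in place of hydrogen on an aromatic carbon. It is the same kind of change as from compound 1 to compound 2 but not the same: there the fluoro entered ortho to a chloro group and meta to a large group, here it enters ortho to a large group and meta to a fluoro group.

Going by the values given here, the one measured instance of this kind of change gave no readable size, and compound 3 sits at the limit of > 88000 nM in this assay, at which 1 of the 3 values shown sits. What remains is that compound 2, carrying the added fluoro, still gives 58400 nM in this assay, well away from the toxic end. The step from compound 3 to compound 4 in this assay is therefore expected to be small, about an at least 1.1-fold lower number from compound 3 to compound 4 (0.04 log units; that floor lies within the scatter). Compound 4 is expected to give around 80000 nM in this assay, between 30000 nM and 200000 nM, with a fair chance that only a limit is returned.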

Compound 4, half-maximal cytotoxic concentration: > 84000 nM
Compound 4: a limit, no number (the forecaster's own chance of this, stated with the estimate: 60%); middle value at least 1.0-fold (0.02 log units) from the limit.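

Compound 3 and compound 4 both return only a limit in this assay, so no step can be read between them. The compounds shown leave open how large the change from 4-fluorophenyl to 2,4-difluorophenyl is on this read-out, and whether fluoro in place of hydrogen on an aromatic carbon shifts the half-maximal cytotoxic concentration at all.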